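Cytotoxicity notes on a fused chromene series

The source may report more compounds than this note shows. Statements on the series, on what has been measured and on what is new or still open speak of the compounds shown alone.

Compound 2 `CC1(C)CC(=O)C2=C(C1)OC(N)=C(C#N)C2c1cccc(Oc2ccccc2)c1` stands highest of the two numbers seen in a functional assay on HuTu80 cells (Homo sapiens) for cytotoxicity, read by MTT assay, with a stated time of 48 h (a higher number here means a weaker inhibitor, a lower number a stronger inhibitor), at 900 ug/mL. Among the compounds with values here, its nearest neighbour, compound 1 `COc1cc(C2C(C#N)=C(N)OC3=C2C(=O)CCC3)ccc1O`, gives 208 ug/mL in this assay, a gap beyond the scatter; no single-place step links the two. Compound 3 `CC1(C)CC(=O)C2=C(C1)OC(N)=C(C#N)C2c1cccc(C(F)(F)F)c1` differs from compound 2 by trifluoromethyl in place of phenoxy on an aromatic carbon. Within the data shown here, no measured step of this kind exists, so the direction is open; for compound 3 the expected step is a 1.8-fold lower number from compound 2 to compound 3 (0.26 log units; within the scatter), within or modestly beyond the scatter. Compound 3 is expected to give 500 ug/mL in this assay, with a range of 150 ug/mL to 1500 ug/mL.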

Compound 3, half-maximal inhibitory concentration: 388 ug/mL
Compound 3: the middle estimate sits 1.3-fold (0.11 log units) above what was measured; measured number inside the range.
By their numbers in this assay, from the lowest: compounds 1 and 3 (each within the scatter of the next); then compound 2.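

Within the data shown here, on an aromatic carbon, meta to a large group, trifluoromethyl in place of phenoxy gives in this assay a 2.3-fold lower number from compound 2 to compound 3 (0.37 log units; beyond the scatter) and so toward a stronger inhibitor, the only single-place step so far. The phenoxy ring is therefore not required at this position for the lower number, although the step is modest. Nothing available bears on the reason for this step.

This one step cannot separate the loss of the phenoxy ring from the entry of trifluoromethyl. From the compounds shown here alone, how a methoxy group, a chlorine atom or an amine would read at this position remains open.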